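Series notes: ether-linked cyclic amines at the alpha4/beta2 receptor

This account rests on a few compounds, and the source may have more. Where it says the series, first, only, none or still open, it means among the compounds named here.

Measured compounds:
- compound 1, `c1ccc(OC[C@@H]2CCN2)cc1`: 52 nM
- compound 2, `COc1ccccc1OC[C@@H]1CCCN1`: 53500 nM
- compound 3, `COc1ccccc1OC[C@@H]1CCCN1C`: 9400 nM

All three values come from an assay on cell membranes for displacement of a labelled ligand from Neuronal acetylcholine receptor; alpha4/beta2 (Rattus norvegicus), read by scintillation counting; a higher number here means a weaker inhibitor, a lower number a stronger inhibitor. Compound 1 stands lowest of the three, and its gap to compound 3 and to compound 2 is beyond the scatter in both cases. The difference between the core of compound 1 and the core of compound 2 is not broken down here; the two values show that compound 1 gives a far lower number than compound 2 in this assay.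

Within the five-membered ring series, methyl in place of hydrogen on an amine nitrogen in a ring gives a 5.7-fold lower number from compound 2 to compound 3 (0.76 log units; beyond the scatter).

The unmeasured compound 4, `CN1CC[C@H]1COc1ccccc1`, carries the same kind of change relative to compound 1: methyl in place of hydrogen on an amine nitrogen in a ring. The surroundings of the place are not the same word for word: here the amine nitrogen sits in a four-membered non-aromatic ring with 1 nitrogen, next to the ring atom that bears a group of 8 heavy atoms, whereas in compound 3 it sits in a five-membered non-aromatic ring with 1 nitrogen, next to the ring atom that bears a large group.

Expectation: in this assay compound 4 is estimated to move by a 1.3-fold lower number from compound 1 to compound 4 (0.11 log units; within the scatter), a step of the same direction as the one seen from compound 2 to compound 3 but taken as smaller, because compound 1 already gives 52 nM and the change is carried out on a different core. The estimate for compound 4 is 40 nM, with a range from 8 nM to 200 nM.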

Compound 4, inhibition constant: 101 nM
Compound 4: the middle estimate sits 2.5-fold (0.40 log units) below what was measured, and the stated range covers the measured number.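

In this assay methyl in place of hydrogen on an amine nitrogen in a ring gives a 1.9-fold higher number from compound 1 to compound 4 (0.29 log units; within the scatter) on the core of compound 1, a step that cannot be told from the scatter. Set beside the earlier step, the same change does not carry over at the same size from one core to the other: the same change on two cores in this assay, a 5.7-fold lower number (0.76 log units; beyond the scatter) from compound 2 to compound 3 and a 1.9-fold higher number (0.29 log units; within the scatter) from compound 1 to compound 4, 11-fold (1.04 log units) apart, beyond the scatter of two such steps. The step read on the five-membered ring therefore cannot serve as a fixed increment for the four-membered ring, but one pair on each core does not show which of the differences between the cores accounts for the gap, and it says nothing about any other core.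

The cores of compound 1 and compound 2 differ both in ring size and in the methoxy group, so a methoxy group on the four-membered ring core, or the plain phenyl ether on the five-membered ring core, would be needed to separate the two. Also open, from the compounds shown here alone, is how ethyl or benzyl on the ring nitrogen would compare with methyl on either core.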